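Replacing the aromatic arm of compound 2

The source may report more compounds than this note shows. Statements on the series, on what has been measured and on what is new or still open speak of the compounds shown alone.

Among the measured compounds shown here, compound 2 `CC1=CC[C@@H]([C@@](C)(O)CCCC(C)(C)NC(=S)N/N=C\c2ccc(O)cc2)CC1` is the one member of this small set with a real number: in a functional assay on HT-29 cells (Homo sapiens) for cytotoxicity, read by sulforhodamine B assay (a higher number here means that more compound is tolerated, a lower number that less compound is tolerated), compound 2 gives 58500 nM. Compound 1 `COc1ccc(/C=N\NC(=S)NC(C)(C)CCC[C@](C)(O)[C@@H]2CC=C(C)CC2)cc1` reaches only a limit of the assay, > 100000 nM. Compound 3 `CC1=CC[C@@H]([C@@](C)(O)CCCC(C)(C)NC(=S)N/N=C\c2ccc([N+](=O)[O-])cc2)CC1` likewise stops at a limit, > 100000 nM. The shift from compound 1 to compound 2 is an at least 1.7-fold lower number from compound 1 to compound 2 (0.23 log units; that floor lies within the scatter), and that from compound 2 to compound 3 is an at least 1.7-fold higher number from compound 2 to compound 3 (0.23 log units; that floor lies within the scatter); both rest on (the limit of > 100000 nM in this assay, at which 2 of the 3 values shown sit). Compound 4 `CC1=CC[C@@H]([C@@](C)(O)CCCC(C)(C)NC(=S)N/N=C(/C)c2ccccc2)CC1` differs from compound 2 by a group of 9 heavy atoms (8 carbon, 1 nitrogen; one six-membered aromatic ring of carbon only) in place of a group of 9 heavy atoms (7 carbon, 1 nitrogen, 1 oxygen; one six-membered aromatic ring of carbon only), on an amide-type nitrogen, so the hydroxy is gone. Since compound 1 and compound 3 sit at the limit of > 100000 nM in this assay, at which 2 of the 3 values shown sit, the expected step is a 1.7-fold higher number from compound 2 to compound 4 (0.23 log units; within the scatter), an upward move that may itself end at a limit. The estimate for compound 4 is 100000 nM, within 40000 nM to 300000 nM.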

Compound 4, concentration lethal to 50% of the cells: > 100000 nM
Compound 4: only a limit was reported (the forecaster's own chance of this, stated with the estimate: 60%); the middle value lies on the limit itself.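

At this place on the amide-type nitrogen, the group entering in compound 4 keeps the six-membered aromatic ring but has no hydroxy, and the result is an at least 1.7-fold higher number from compound 2 to compound 4 (0.23 log units; that floor lies within the scatter). The value for compound 4 is only a limit, so the step from compound 1 to compound 4 cannot be read. A fuller picture of this change is blocked by a shared ceiling: the limit of > 100000 nM in this assay, at which 3 of the 4 values shown sit.

On these data alone, whether an aromatic ring carrying an amine or a carboxylic acid would give a real number remains open. So does the true size of the step to compound 4.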